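Opening a ring: from cyclopentyl ether to pentynyl ether

The source may hold more compounds than are shown below. What is called first, only, known or untested is meant among the compounds shown, and "the series" means these compounds.

Three compounds share one core, an aminoquinoline bearing an ether, and differ only in the group on that ether oxygen. Compound 1 `Nc1ccc2cccc(OC3CCC3)c2n1` carries a cyclobutyl group, compound 2 `CCCCOc1cccc2ccc(N)nc12` a butyl chain, and compound 3 `Nc1ccc2cccc(OC3CCCC3)c2n1` a cyclopentyl ring. In an assay on cells with melanin-concentrating hormone receptor 1 (Homo sapiens) as the target, read by radioligand binding (on this read-out higher numbers stand for weaker inhibition and lower numbers for stronger inhibition), compound 2 gives 789 nM. For compound 1 the value is a limit of the method, > 2000 nM. For compound 3 the value is likewise only a limit, > 2000 nM, so where compound 3 truly stands is not known beyond (the limit of > 2000 nM in this assay, at which 2 of the 3 values shown sit). The steps around it read as an at least 2.5-fold lower number from compound 1 to compound 2 (0.40 log units; beyond the scatter), as an at least 2.5-fold higher number from compound 2 to compound 3 (0.40 log units; beyond the scatter), and as a step that the two limits leave unreadable from compound 1 to compound 3.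

Compound 4 `CCC#CCOc1cccc2ccc(N)nc12` keeps this core and makes the change (pent-2-yn-1-yl in place of cyclopentyl on an oxygen on an aromatic ring). The open five-carbon chain with a triple bond resembles the butyl chain of compound 2 more than the ring of compound 3. The two readable steps, an at least 2.5-fold lower number from compound 1 to compound 2 (0.40 log units; beyond the scatter) and an at least 2.5-fold higher number from compound 2 to compound 3 (0.40 log units; beyond the scatter), both point the same way: the open chain gave a lower number than either ring. A lower number in this assay is therefore expected for compound 4, close to what the butyl compound showed. Compound 4 is estimated at 900 nM, with a likely range from 300 nM to 2500 nM. That estimate means an expected step of an at least 2.2-fold lower number from compound 3 to compound 4 (0.34 log units; beyond the scatter).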

Compound 4, half-maximal inhibitory concentration: > 2000 nM
Compound 4: a limit, no number (the forecaster's own chance of this, stated with the estimate: 25%); middle value at least 2.2-fold (0.34 log units) from the limit.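

In this assay compound 4 gives > 2000 nM, which is a limit of the method and not a number. Having an open chain on this oxygen is therefore not enough on its own: the pent-2-yn-1-yl group has no ring, yet the change from the butyl chain gives an at least 2.5-fold higher number from compound 2 to compound 4 (0.40 log units; beyond the scatter), so compound 4 goes against the idea, suggested by the earlier compounds, that open chains do better here than rings, and compound 2 remains the only compound with a readable value. The steps to compound 4 from compound 1 and from compound 3 cannot be read, because each of them joins two limits: the limit of > 2000 nM in this assay, at which 3 of the 4 values shown sit.

The butyl and pent-2-yn-1-yl groups differ both in chain length and in the triple bond, so the compounds shown cannot tell which of the two matters, and a plain pentyl chain would separate them. Also open, going by these compounds, are whether a shorter propyl chain, or a butyl chain carrying an amine, would give a lower number than compound 2 does.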